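The source may report more compounds than this note shows. Statements on the series, on what has been measured and on what is new or still open speak of the compounds shown alone.

Compound 1 `C/C(=C\CC/C(C)=C/CC[C@@H]1[C@@]2(C)CCC(=O)C(C)(C)[C@H]2CC[C@@]1(C)O)CC/C=C(\C)C(=O)OCc1cn(-c2ccc(F)cc2)nn1` carries a 4-fluorophenyl group on an aromatic nitrogen of the shared core. In an ADME assay on L132 cells (Homo sapiens) for cytotoxicity, read by MTT assay, with a stated time of 48 h (on this read-out lower numbers stand for stronger inhibition and higher numbers for weaker inhibition), compound 1 gives only a limit of the assay, > 150000 nM, and no number. Compound 2 `COc1ccccc1-n1cc(COC(=O)/C(C)=C/CC/C(C)=C/CC/C(C)=C/CC[C@@H]2[C@@]3(C)CCC(=O)C(C)(C)[C@H]3CC[C@@]2(C)O)nn1` bears 2-methoxyphenyl in place of 4-fluorophenyl on that aromatic nitrogen. In this assay compound 2 also gives only a limit, > 150000 nM. Compound 3 `C/C(=C\CC/C(C)=C/CC[C@@H]1[C@@]2(C)CCC(=O)C(C)(C)[C@H]2CC[C@@]1(C)O)CC/C=C(\C)C(=O)OCc1cn(-c2ccccc2C(F)(F)F)nn1` bears 2-(trifluoromethyl)phenyl in place of 4-fluorophenyl on an aromatic nitrogen. In this assay compound 3 likewise reaches only a limit, > 150000 nM. Hence the step that the two limits leave unreadable from compound 1 to compound 2, the step that the two limits leave unreadable from compound 1 to compound 3 and the step that the two limits leave unreadable from compound 2 to compound 3 cannot be sized: all three compounds sit at the limit of > 150000 nM in this assay, at which 3 of the 3 values shown sit. Compound 4 `COc1ccc(-n2cc(COC(=O)/C(C)=C/CC/C(C)=C/CC/C(C)=C/CC[C@@H]3[C@@]4(C)CCC(=O)C(C)(C)[C@H]4CC[C@@]3(C)O)nn2)cc1` has not yet been measured. It differs from compound 1 by methoxy in place of fluoro on an aromatic carbon. The measured steps bear on this change only in that every variation of the group on this aromatic ring left the compound at the limit; none of them shows a readable size. Compound 4 is therefore expected to remain at the same limit, so that no step beyond the scatter, a step that the limit leaves unreadable from compound 1 to compound 4, is expected. For compound 4 the estimate in this assay is 200000 nM, with a range from 100000 nM to 400000 nM.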

Compound 4, half-maximal inhibitory concentration: > 150000 nM
Compound 4 ended at the assay's limit (the forecaster's own chance of this, stated with the estimate: 85%); the middle value is on the limit's open side.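

In this assay, among these compounds, compound 4 also gives only a limit, so no step between compound 4 and compound 1, compound 2 or compound 3 can be read, and all four compounds stand at the same place: the limit of > 150000 nM in this assay, at which 4 of the 4 values shown sit. The compounds shown leave open whether any group on the aromatic nitrogen would give a measurable value in this assay at all.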